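The compounds below may be only part of what the source reports. "The series", "measured", "known", "first", "only" and "open" are said of these compounds alone.

Series notes. Among the measured compounds shown here, compound 1 `CCn1c(=O)n(C2OC(CO)[C@@H](O)[C@H]2O)c2nc(N)nc(O)c21` in a functional assay on the whole organism with Mus musculus as the target (a higher number here means a larger maximal response, a lower number a smaller maximal response), gives 82%, the higher of the two numbers measured so far. Compound 2 `CCCn1c(=O)n(C2CCC(CO)O2)c2nc(NC(=O)C(C)(C)C)nc(O)c21` in this assay gives 4%; it differs from compound 1 in several places at once, so the two values are only set side by side. Compound 3 `Nc1nc(O)c2c(n1)n(C1OC(CO)[C@@H](O)[C@H]1O)c(=O)n2Cc1ccc([N+](=O)[O-])cc1` is not yet measured in this assay. Relative to compound 1 it carries 4-nitrophenyl in place of methyl on a saturated chain carbon bound to an aromatic nitrogen. For the measured compounds named here, no measured pair covers this change; a downward step beyond the scatter is expected, with wide uncertainty, since compound 2 gives 4%. The step expected is a number 37 percentage points lower from compound 1 to compound 3 (beyond the scatter). Compound 3 is expected at 45%, between 10% and 85%.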

Compound 3, largest response reached (reported as maximal response), in percent of the reference or control that the assay uses: 16%
For compound 3 the middle estimate is 29 percentage points above the measured one; low and high end bracket the measured number.
By their numbers in this assay, from the lowest: compound 2; then compound 3; then compound 1.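

Among the compounds shown here, this is the first comparison that differs in one place only. In this assay, 4-nitrophenyl in place of methyl on a saturated chain carbon bound to an aromatic nitrogen gives a number 66 percentage points lower from compound 1 to compound 3 (beyond the scatter), so the maximal response depends on the group carried at this position. Nothing available bears on the reason for this drop.

Still open, on these data alone, is whether the drop follows the aromatic ring or the nitro group. An unsubstituted benzyl or a 4-aminobenzyl at this place would separate the two.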